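Swapping Acetyl for Cyanomethyl on an Amine Nitrogen

A few compounds are considered here, and "the series" means these few. Any claim that something is new, unique, unknown or untested is made for them only; others in the source may bear on it.

Compound 1 `C#CCN(CCC)Cc1cn(-c2cc(NC(=S)NCC)ncn2)cn1`: in an assay on isolated protein for inhibition of Amine oxidase [flavin-containing] A (Homo sapiens), read by fluorescence and Amplex Red, with a stated time of 15 min (a higher number here means a weaker inhibitor, a lower number a stronger inhibitor), compound 1 gives > 50000 nM, a limit of the assay.
Compound 2 `C#CCN(Cc1cn(-c2cc(NC(=S)NCC)ncn2)cn1)C(C)=O`: in this assay compound 2 gives > 50000 nM, also a limit.

Compound 2 thus stands at the assay limit, as the limit of > 50000 nM in this assay, at which 2 of the 2 values shown sit, records, so the step that the two limits leave unreadable from compound 1 to compound 2 cannot be read. Compound 3 `C#CCN(CC#N)Cc1cn(-c2cc(NC(=S)NCC)ncn2)cn1` differs from it by cyanomethyl in place of acetyl on an amine nitrogen. Among the compounds with values here, no measured step bears on this change, and no direction can be drawn from the two limits. Compound 3 is expected to stay at the limit, an estimated 50000 nM within 10000 nM to 200000 nM. The expected step is a number no higher from compound 2 to compound 3 (the limit leaves the size open).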

Compound 3, half-maximal inhibitory concentration: > 50000 nM
Compound 3 was reported as a limit (the forecaster's own chance of this, stated with the estimate: 75%); the middle value sits exactly at the limit.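

Within the data shown here, no step among compound 1, compound 2 and compound 3 can be read, since each value is only a limit of the assay: the limit of > 50000 nM in this assay, at which 3 of the 3 values shown sit. The compounds shown leave open which group on the amine nitrogen, if any, would give a measurable value in this assay.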